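Chloro to methoxy on the aryl ring: a repeated swap

The source may report more compounds than this note shows. Statements on the series, on what has been measured and on what is new or still open speak of the compounds shown alone.

Three members of this series have numbers in a functional assay on the whole organism (strain Sprague-Dawley) for inhibition, with Rattus norvegicus as the target, with a stated time of 10 min; on this read-out higher numbers stand for an effect only at larger amounts of compound and lower numbers for an effect already at smaller amounts. Compound 1 `O=C(O)c1cnc(-c2ccccc2Cl)[nH]c1=O` gives 5 mg/kg in this assay. Compound 2 `COc1ccccc1-c1ncc(C(=O)O)c(=O)[nH]1` carries methoxy in place of chloro on an aromatic carbon and gives 10 mg/kg in this assay; the step is a 2.0-fold higher number from compound 1 to compound 2 (0.30 log units; within the scatter), so compound 1 and compound 2 cannot be told apart on this read-out. Compound 3 `CCOC(=O)c1cnc(-c2cc(Cl)ccc2OCC)[nH]c1=O` gives 0.5 mg/kg in this assay, the lowest of the three numbers; the difference between its core and the core of compound 1 is not broken down here, the two differing in more than one place.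

Compound 4 `CCOC(=O)c1cnc(-c2cc(OC)ccc2OCC)[nH]c1=O` is not yet measured. It differs from compound 3 by methoxy in place of chloro on an aromatic carbon. This is the same kind of change as that from compound 1 to compound 2, not the same: in compound 2 the entering group sits ortho to a large group, whereas in compound 4 it sits meta to a large group and para to an ethoxy group. Among the compounds with values here, with only one earlier instance of the swap, and that one within the scatter, the expectation for compound 4 rests on the unchanged reading of compound 3 at 0.5 mg/kg and on the step of a 2.0-fold higher number from compound 1 to compound 2 (0.30 log units; within the scatter), which is taken as the likeliest direction. The expected step is therefore a 2.0-fold higher number from compound 3 to compound 4 (0.30 log units; within the scatter). Compound 4 is estimated to give 1 mg/kg in this assay, with a range from 0.4 mg/kg to 2.5 mg/kg reflecting the uncertainty of carrying one in-scatter step onto a different core.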

Compound 4, dose for 50% inhibition: 0.3 mg/kg
The estimate for compound 4 lay 3.3-fold (0.52 log units) above the measured number; the measured number lies below the stated range.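

In this assay, replacing chloro with methoxy gives a 1.7-fold lower number from compound 3 to compound 4 (0.22 log units; within the scatter), so the two compounds cannot be told apart on this read-out. With only two instances, and with the core of compound 1 and the core of compound 3 differing in more than one place, the data do not show which of those differences separates the two steps. They also do not show whether the placing of the methoxy in compound 4, meta to a large group and para to an ethoxy group, plays any part, or how a third core would respond. What they do show is that this swap cannot be carried from one core to another as a fixed shift: the same change on two cores in this assay, a 2.0-fold higher number (0.30 log units; within the scatter) from compound 1 to compound 2 and a 1.7-fold lower number (0.22 log units; within the scatter) from compound 3 to compound 4, 3.3-fold (0.52 log units) apart, beyond the scatter of two such steps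

The compounds shown leave open what the ethyl ester and the ethoxy group each contribute on their own, and whether the swap would read the same on a core carrying only one of them. Also open, on these data alone, is how other groups in the place of the chloro, such as fluoro, an amine or a longer alkoxy chain, would read in this assay.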